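This account rests on a few compounds, and the source may have more. Where it says the series, first, only, none or still open, it means among the compounds named here.

Three nucleoside analogues built on one shared core were tested in a functional assay on LOX cells (Homo sapiens) for antiproliferative activity, read by WST assay, with a stated time of 3 days; on this read-out lower numbers stand for stronger inhibition and higher numbers for weaker inhibition. Compound 1 `[N-]=[N+]=Nc1cc(=O)[nH]c(=O)n1[C@@H]1O[C@H](CO)[C@@H](O)[C@H]1O` carries an azido group on the core, compound 2 `Nc1cc(=O)[nH]c(=O)n1[C@@H]1O[C@H](CO)[C@@H](O)[C@H]1O` carries an amino group in its place, and compound 3 `[N-]=[N+]=Nc1c(F)c(=O)[nH]c(=O)n1[C@@H]1O[C@H](CO)[C@@H](O)[C@H]1O` keeps the azido group and adds a fluoro group. In this assay compound 1 gives only a limit, > 50000 nM. Compound 2 likewise gives only a limit, > 50000 nM. Compound 3 gives a real number, 2300 nM, the only one among the three.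

The change from compound 1 to compound 2 is amino in place of azido on an aromatic carbon. The step it made, a step that the two limits leave unreadable from compound 1 to compound 2, cannot be read because both values sit at the limit of > 50000 nM in this assay, at which 2 of the 3 values shown sit. The two cores differ by fluoro in place of hydrogen on an aromatic carbon, and that step is an at least 21-fold lower number from compound 1 to compound 3 (1.33 log units; beyond the scatter).

Compound 4 `Nc1c(F)c(=O)[nH]c(=O)n1[C@@H]1O[C@H](CO)[C@@H](O)[C@H]1O` has not yet been measured. It differs from compound 3 by amino in place of azido on an aromatic carbon. Going by the values given here, this is the same kind of change as the one from compound 1 to compound 2, but not the same: here the place is also ortho to a fluoro group (1 heavy atom), which is absent from the place in compound 1.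

The expectation for compound 4 rests on compound 3 with its value 2300 nM and on the unreadable step that the two limits leave unreadable from compound 1 to compound 2, which leaves the direction of the azido-to-amino change open. Compound 4 is therefore expected to come out weaker than compound 3, at an estimated 12000 nM, most likely between 2500 nM and 50000 nM. The expected step is a 5.2-fold higher number from compound 3 to compound 4 (0.72 log units; beyond the scatter), with a fair chance that only a limit is reported.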

Compound 4, half-maximal inhibitory concentration: 3400 nM
Compound 4: the middle estimate sits 3.5-fold (0.55 log units) above what was measured, within the range that was stated.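

In this assay, amino in place of azido on the core that carries the fluoro group gives a 1.5-fold higher number from compound 3 to compound 4 (0.17 log units; within the scatter), so the two groups cannot be told apart on this core. Fluoro in place of hydrogen on the core with the amino group gives an at least 14-fold lower number from compound 2 to compound 4 (1.16 log units; beyond the scatter), so in these two pairs the fluoro change goes the same way and is large on both the azido and the amino core: the same change on two cores in this assay, an at least 21-fold lower number (1.33 log units; beyond the scatter) from compound 1 to compound 3 and an at least 14-fold lower number (1.16 log units; beyond the scatter) from compound 2 to compound 4; the limit leaves it open whether they differ. On these data alone, the true size of either fluoro step remains unknown, as does whether one is larger than the other, and the step from compound 1 to compound 2 cannot be read either, because the compounds without fluoro give only a limit and no number: the limit of > 50000 nM in this assay, at which 2 of the 4 values shown sit.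

The compounds shown leave open whether a chloro or a methyl group in the place of the fluoro group would lower the number in the same way. They also leave open whether the fluoro step would carry over to a core with a methylamino or a hydroxyl group in the place of the azido or amino group.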